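This account rests on a few compounds, and the source may have more. Where it says the series, first, only, none or still open, it means among the compounds named here.

Compound 1 `FC(F)(F)c1ccc(CN2CCN(Cc3cc(-c4ccc(OCc5ccccc5)cc4)on3)CC2)cc1`: 11700 nM
Compound 2 `Cc1ccc(COc2ccc(-c3cc(CN4CCN(Cc5ccc(C(F)(F)F)cc5)CC4)no3)cc2)cc1`: 7500 nM
Compound 3 `N#Cc1cccc(COc2ccc(-c3cc(CN4CCN(Cc5ccc(C(F)(F)F)cc5)CC4)no3)cc2)c1`: 10600 nM

All three were tested in a functional assay on Mahlavu cells (Homo sapiens) for antiproliferative activity, read by sulforhodamine B assay, with a stated time of 72 h; a lower number here means a stronger inhibitor, a higher number a weaker inhibitor. Compound 2 differs from compound 1 by methyl in place of hydrogen on an aromatic carbon, a change that gave a 1.6-fold lower number from compound 1 to compound 2 (0.19 log units; within the scatter). Compound 3 differs from compound 1 by cyano in place of hydrogen on an aromatic carbon, and that gave a 1.1-fold lower number from compound 1 to compound 3 (0.04 log units; within the scatter). Compound 4 `Cc1cc(OCc2cccc(C#N)c2)ccc1-c1cc(CN2CCN(Cc3ccc(C(F)(F)F)cc3)CC2)no1` has not yet been measured in this assay; it differs from compound 3 by methyl in place of hydrogen on an aromatic carbon. Within the data shown here, this is the same kind of change as the one from compound 1 to compound 2, but the place differs: there the methyl sat para to a large group, here it sits ortho to a large group and meta to a (3-cyanobenzyl)oxy group, on a core that differs as just described. Because the earlier instance gave a 1.6-fold lower number from compound 1 to compound 2 (0.19 log units; within the scatter), a step of similar size is expected, a 1.3-fold lower number from compound 3 to compound 4 (0.12 log units; within the scatter). Compound 4 is therefore estimated at 8000 nM, between 4000 nM and 16000 nM.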

Compound 4, half-maximal inhibitory concentration: 500 nM
Compound 4: the middle estimate sits 16-fold (1.20 log units) above what was measured, and the stated range ends above it.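

In this assay, methyl in place of hydrogen on an aromatic carbon gave a 21-fold lower number from compound 3 to compound 4 (1.33 log units; beyond the scatter), and this step did not repeat what the same change did earlier: the same change on two cores in this assay, a 1.6-fold lower number (0.19 log units; within the scatter) from compound 1 to compound 2 and a 21-fold lower number (1.33 log units; beyond the scatter) from compound 3 to compound 4, 14-fold (1.13 log units) apart, beyond the scatter of two such steps The size of this change therefore did not carry from one core to the other in this series, at least for these two pairs. It does not show whether the place of the methyl or the rest of the core accounts for the gap; the two steps differ in both.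

Open, from the compounds shown here alone, is whether a methyl at the place it holds in compound 4 would give a step of this size on the core of compound 1 or compound 2. Also open, going by these compounds, is whether an ethyl, a methoxy or a chlorine at that place would act as the methyl does.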